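The source may hold more compounds than are shown below. What is called first, only, known or untested is meant among the compounds shown, and "the series" means these compounds.

Among the compounds with values here, in a functional assay on A2780 cells (Homo sapiens) for inhibition (a higher number here means a weaker inhibitor, a lower number a stronger inhibitor), two compounds built on one shared core have numbers so far. Compound 1 (`CC(C(=O)Nc1cc(C2CC2)[nH]n1)c1ccc(N2Cc3ccccc3C2=O)cc1`) gives 4750 nM in this read-out, and compound 2 (`CC(C(=O)Nc1cc(C2CC2)[nH]n1)c1ccc(N2CCC(C(N)=O)C2=O)cc1`) gives 5710 nM there. These two values lie within the scatter of each other, so compound 2 stands level with compound 1 on the numbers shown. Compound 3 (`CC(C(=O)Nc1cc(C2CC2)[nH]n1)c1ccc(N2CCCC2)cc1`) keeps the shared core and differs from compound 2 in one place, on an aromatic carbon of a six-membered aromatic ring of carbon only, para to a large group: a group of 5 heavy atoms (4 carbon, 1 nitrogen; one five-membered non-aromatic ring with 1 hetero atom) in place of a group of 9 heavy atoms (5 carbon, 2 nitrogen, 2 oxygen; one five-membered non-aromatic ring with 1 hetero atom), on an aromatic carbon is the change, and pyrrolidin-1-yl is the group that enters. Within the data shown here, no measured pair isolates a change of this kind, so the data give no direct guide to its size or direction. Compound 1 at 4750 nM and compound 2 at 5710 nM carry different groups in this place and still fall within the scatter. On that basis, a small step is expected in this assay, with no firm direction: the estimated step is a 1.4-fold lower number from compound 2 to compound 3 (0.15 log units; within the scatter) and stays within the scatter. For compound 3 the estimate is 4000 nM with an expected range from 1200 nM to 13000 nM in this read-out.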

Compound 3, half-maximal inhibitory concentration: 370 nM
The estimate for compound 3 lay 11-fold (1.03 log units) above the measured number; the whole stated range lies above it.
By their numbers in this assay, from the lowest: compound 3; then compounds 1 and 2 (each within the scatter of the next).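

In this assay, the pyrrolidin-1-yl group on this aromatic carbon, para to a large group, gives a 15-fold lower number from compound 2 to compound 3 (1.19 log units; beyond the scatter) and so shows that this place can carry a large change. Compounds 1 and 2 could not show this, since their different groups here left them within the scatter of each other. The group that leaves carries a hydrogen-bond donor and double bonds outside aromatic rings while pyrrolidin-1-yl carries neither, but these differences and the smaller size of the group all arrive in one step, so the data cannot separate them, and nothing on hand gives a measured reason for the difference.

On these data alone, what a piperidine ring or an open-chain dimethylamino group would give at this place stays open, and so does whether the ring size or the nitrogen attached to the aromatic carbon matters more. As far as these compounds go, it is also open whether a pyrrolidine ring bearing only a carboxylic acid or a primary amide would fall closer to compound 3 or to compound 2.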